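A Growth-Inhibition Step with Little to Go On

The compounds below may be only part of what the source reports. "The series", "measured", "known", "first", "only" and "open" are said of these compounds alone.

Measured in a functional assay on MDA-MB-231 cells (Homo sapiens) for inhibition, read by sulforhodamine B assay, with a stated time of 72 h; a lower number here means a stronger inhibitor of growth, a higher number a weaker inhibitor of growth:
compound 1 `O=C(CCc1ccncc1-c1ccc2ccccc2c1)N1CCOCC1`: > 10000 nM (a limit, not a number)
compound 2 `CNC(=O)CCc1ccncc1-c1ccc2ccccc2c1`: 8980 nM
compound 3 `O=C(O)/C=C/c1ccncc1-c1ccc2cc[nH]c2c1`: > 10000 nM (a limit, not a number)

Within the data shown here, compound 2 gives 8980 nM, the only true number in this assay. The other two results are described by the limit of > 10000 nM in this assay, at which 2 of the 3 values shown sit.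

The next compound is compound 4 `O=C(/C=C/c1ccncc1-c1ccc2ccccc2c1)NC1CC1`, which differs from compound 2 in one place: 2-(cyclopropylcarbamoyl)ethenyl in place of 2-(methylcarbamoyl)ethyl on an aromatic carbon. There, 2-(cyclopropylcarbamoyl)ethenyl stands in place of 2-(methylcarbamoyl)ethyl on an aromatic carbon, ortho to a large group and opposite the ring nitrogen.

Among the measured compounds shown here, only one measured step bears on this change: an at least 1.1-fold lower number from compound 1 to compound 2 (0.04 log units; that floor lies within the scatter). That step puts methylamino in place of morpholin-4-yl on a carbonyl carbon. For the measured compounds named here, no measured step covers the change from ethyl to ethenyl or the arrival of the three-membered ring. No step beyond the scatter is therefore expected in this assay, in either direction. The expected step is a 1.5-fold lower number from compound 2 to compound 4 (0.18 log units; within the scatter). For compound 4 the estimate is 6000 nM, with an expected range of 2000 nM to 10000 nM.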

Compound 4, concentration for 50% growth inhibition: 8420 nM
Estimate against measurement, compound 4: 1.4-fold (0.15 log units) below, within the range that was stated.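

The step at this position, ortho to a large group and opposite the ring nitrogen, reads a 1.1-fold lower number from compound 2 to compound 4 (0.03 log units; within the scatter) in this assay. Compounds 1 and 2 differ only in the group on the carbonyl carbon, whereas this step shows that the chain itself can take a second double bond and a three-membered ring together with no change beyond the scatter. Compound 4 gives a second true number, but the two changes arrive together and the series still offers little to read: the limit of > 10000 nM in this assay, at which 2 of the 4 values shown sit.

From the compounds shown here alone, it remains open whether the ethenyl link or the cyclopropyl group alone would give a step of its own. Going by these compounds, it also remains open whether a longer chain or a free primary amine in this place would move the number beyond the scatter.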